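Adding a Second Methoxy to the Best of Three

The source may report more compounds than this note shows. Statements on the series, on what has been measured and on what is new or still open speak of the compounds shown alone.

Compound 1 `CC(=O)c1cc2ccc(OCCCCCn3cc(CNC(=O)CCCCC4CCSS4)nn3)cc2oc1=O` gives 20.7% in a functional assay on PC-12 cells (Rattus norvegicus) for cytotoxicity, read by MTT assay, with stated times of 3 h and 2 h, tested at 20 uM; on this read-out lower numbers stand for a weaker effect and higher numbers for a stronger effect at the one concentration tested.
Compound 2 `O=C(CCCCC1CCSS1)NCc1cn(CCCCCOc2ccc3cc(-c4ccccc4)c(=O)oc3c2)nn1` gives 20.7% in this assay.
Compound 3 `COc1ccc(-c2cc3ccc(OCCCCCn4cc(CNC(=O)CCCCC5CCSS5)nn4)cc3oc2=O)cc1` gives 49% in this assay.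

Compound 3 thus holds the highest of the three numbers, its steps to compound 1 and to compound 2 both lying beyond the scatter. Compound 4 `COc1ccc(-c2cc3ccc(OCCCCCn4cc(CNC(=O)CCCCC5CCSS5)nn4)cc3oc2=O)cc1OC` differs from compound 3 in one place: methoxy in place of hydrogen on an aromatic carbon. The measured step that bears most directly on this change is a number 28.3 percentage points higher from compound 2 to compound 3 (beyond the scatter), a modest gain. By contrast, no change at the digits printed from compound 1 to compound 2 (within the scatter) stayed within the scatter, while a number 28.3 percentage points higher from compound 1 to compound 3 (beyond the scatter) carried the same modest gain. A second methoxy need not repeat that gain in full, so compound 4 is expected to give a similar or somewhat higher number, a number 6 percentage points higher from compound 3 to compound 4 (within the scatter). Compound 4 is estimated at 55% with a range from 35% to 75%.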

Compound 4, a percentage reported as activity, at one concentration (the size of the read-out at that concentration, not a potency): 51.9%
The estimate for compound 4 lay 3.1 percentage points above the measured number, and the stated range covers the measured number.
By their numbers in this assay, from the lowest: compounds 1 and 2 (each within the scatter of the next); then compounds 3 and 4 (each within the scatter of the next).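

In this assay, a methoxy placed ortho to a methoxy group gives a number 2.9 percentage points higher from compound 3 to compound 4 (within the scatter), so this second methoxy does not repeat what the first one did in the step of a number 28.3 percentage points higher from compound 2 to compound 3 (beyond the scatter). The 3,4-dimethoxyphenyl group keeps the large steps of a number 31.2 percentage points higher from compound 2 to compound 4 (beyond the scatter) and a number 31.2 percentage points higher from compound 1 to compound 4 (beyond the scatter). Nothing at hand explains why the second methoxy differs from the first.

On these data alone, whether a hydroxyl group or an amine at this place on the ring would read any differently from methoxy remains open, as does the effect of a longer ether such as ethoxy.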